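Cytotoxicity in the amide side-chain series

The source may report more compounds than this note shows. Statements on the series, on what has been measured and on what is new or still open speak of the compounds shown alone.

Among the measured compounds shown here, compound 2 `CC(CN)NC(=O)c1cc(C2CC2)nc2c1cnn2C(C)C` is the one compound with a number in an ADME assay on Vero cells (Chlorocebus sabaeus) for cytotoxicity, read by neutral red uptake, with a stated time of 3 days (a higher number here means that more compound is tolerated, a lower number that less compound is tolerated), where compound 2 gives 164000 nM. Compound 1 `CC(CN(C)C)NC(=O)c1cc(C2CC2)nc2c1cnn2C(C)C` sits at a limit of the assay, > 300000 nM. The step of an at least 1.8-fold lower number from compound 1 to compound 2 (0.26 log units; that floor lies within the scatter) lies within the scatter. Compound 3 `CC(C)n1ncc2c(C(=O)NCCCN(C)C)cc(C3CC3)nc21` differs from compound 2 by 3-(dimethylamino)propyl in place of 1-(aminomethyl)ethyl on an amide-type nitrogen. Compound 1, which carries a dimethylamino group, stands at the limit of > 300000 nM in this assay, at which 1 of the 2 values shown sits. Compound 3 carries that dimethylamino group too. The step from compound 2 to compound 3 is expected at a 1.8-fold higher number from compound 2 to compound 3 (0.26 log units; within the scatter), towards more tolerated compound, though not clearly beyond the scatter. Compound 3 is estimated at 300000 nM, within 130000 nM to 700000 nM.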

Compound 3, half-maximal cytotoxic concentration: > 200000 nM
Compound 3 gave a limit, no number; the forecaster's own chance of this, stated with the estimate: 50%; the middle value does not contradict the limit.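

With 3-(dimethylamino)propyl on the amide-type nitrogen, compound 3 also gives a limit rather than a number in this assay: the limit of > 200000 nM in this assay, at which 1 of the 3 values shown sits. The change gives an at least 1.2-fold higher number from compound 2 to compound 3 (0.08 log units; that floor lies within the scatter), so it does not separate the two compounds. The step between compound 1 and compound 3, two limits, cannot be read.

Open, going by these compounds, is where compound 3 would fall if it gave an actual number. Also open, on these data alone, is whether a carboxylic acid in place of the dimethylamino group, or a longer chain, would give a number in this assay.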